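The source may report more compounds than this note shows. Statements on the series, on what has been measured and on what is new or still open speak of the compounds shown alone.

Compound 1 `CCNC(=O)c1nc(-c2cc(OC)c(OC)c(OC)c2)n(-c2ccc(OC)cc2)n1` carries an ethyl group on its amide-type nitrogen. In a functional assay on the whole organism for inhibition, with Rattus norvegicus as the target, read by paw edema, with stated times of 30 min and 3 h, at a dose of 0.28 mmol/kg by the oral route (a lower number here means less inhibition, a higher number more inhibition at the dose given (going by the name of the read-out)), compound 1 gives 101%, the higher of the two numbers available. Compound 2 `COc1ccc(-n2nc(C(=O)Nc3ccccc3C)nc2-c2cc(OC)c(OC)c(OC)c2)cc1` differs from it only in having 2-methylphenyl in place of ethyl on the amide-type nitrogen, and in this assay compound 2 gives 74%; the step is a number 27 percentage points lower from compound 1 to compound 2 (beyond the scatter), a modest fall that lies beyond the scatter.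

Compound 3 `COc1ccc(-n2nc(C(=O)Nc3ccccc3)nc2-c2cc(OC)c(OC)c(OC)c2)cc1` is the counterpart with a plain phenyl on that nitrogen: phenyl in place of ethyl on an amide-type nitrogen. No measurement of compound 3 in this assay is known. Among the compounds with values here, the one comparison that bears on this change is the step from compound 1 to compound 2, in which an aryl group replacing ethyl on the amide-type nitrogen lowered the number by a number 27 percentage points lower from compound 1 to compound 2 (beyond the scatter). Since phenyl is a closely related aryl group, a fall of similar kind is expected, though its size is uncertain.

Compound 3 is therefore estimated at 80%, within a range from 62% to 98%, which means an expected step of a number 21 percentage points lower from compound 1 to compound 3 (beyond the scatter).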

Compound 3, a percentage reported as inhibition, in the whole organism at one dose (the size of the read-out at that dose, not a potency): 79%
Compound 3: the middle estimate sits 1 percentage points above what was measured; the measured number falls inside the stated range.
By their numbers in this assay, from the lowest: compounds 2 and 3 (each within the scatter of the next); then compound 1.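

In this assay, a second aryl group on the amide-type nitrogen shows the same kind of loss, with a number 22 percentage points lower from compound 1 to compound 3 (beyond the scatter), so the fall from ethyl does not rest on the methyl group of the 2-methylphenyl substituent. That methyl group itself makes no readable difference at this position, since replacing it with hydrogen gives a number 5 percentage points higher from compound 2 to compound 3 (within the scatter), and the two aryl amides cannot be told apart in this read-out. Among the compounds shown, the ethyl amide therefore stands apart from both aryl amides, but nothing available explains that separation.

The compounds shown leave open whether the fall follows from the aromatic ring itself or from replacing a short chain with a larger group, a question that a cyclohexyl group or a longer chain such as butyl on the same nitrogen would address. They also leave open whether the aryl amides can regain the level of compound 1 when the phenyl ring carries a different group, such as an amine or a carboxylic acid.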